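This account rests on a few compounds, and the source may have more. Where it says the series, first, only, none or still open, it means among the compounds named here.

For the measured compounds named here, compound 1 `Clc1cccc2sc(Nc3nc4ccccc4s3)nc12` gives 29500 nM in a functional assay on B16-F10 cells (Mus musculus) for cytotoxicity, read by MTT assay, with a stated time of 48 h (a lower number here means a stronger inhibitor, a higher number a weaker inhibitor), the only plain number among the three measured compounds. Compound 2 `CCOc1ccc2nc(NC(=S)Nc3ccccc3)sc2c1` is reported in this assay only as a limit, > 50000 nM. Compound 3 `S=C(Nc1ccccc1)Nc1nc2c(Cl)cccc2s1` likewise reaches only a limit in this assay, > 50000 nM. Compound 2 therefore stands not at a number but at the edge of the assay, as the limit of > 50000 nM in this assay, at which 2 of the 3 values shown sit, records, alongside compound 3 and apart from compound 1. Compound 4 `Fc1ccc2nc(NC(=S)Nc3ccccc3)sc2c1` has not yet been tested in this assay. It differs from compound 2 in one place (fluoro in place of ethoxy on an aromatic carbon). Going by the values given here, no pair of measured compounds differing in a single place is available, so the size of such a change cannot be read from the measured set. Since compound 2 stands at a limit, the writer expects compound 4 to show a step of a number no higher from compound 2 to compound 4 (the limit leaves the size open) that amounts to none beyond the scatter. Compound 4 is estimated at 50000 nM, with a range from 20000 nM to 150000 nM, and most likely again only a limit.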

Compound 4, half-maximal inhibitory concentration: > 50000 nM
Compound 4 gave a limit, no number; the forecaster's own chance of this, stated with the estimate: 70%; the middle value sits exactly at the limit.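

For the compounds shown here, compound 2 and compound 4 are both reported only as limits in this assay, and no step from one to the other can be read. The compounds shown leave open whether fluoro in place of ethoxy on an aromatic carbon changes the inhibitory concentration at all.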